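A few compounds are considered here, and "the series" means these few. Any claim that something is new, unique, unknown or untested is made for them only; others in the source may bear on it.

Two compounds share the core of compound 1 `Cc1ccc(NC(=O)c2cnc(Cl)nc2C(F)(F)F)s1`, and in an assay on Jurkat cells for inhibition of cyclic AMP-dependent transcription factor ATF-1 (Homo sapiens) (a lower number here means a stronger inhibitor, a higher number a weaker inhibitor), compound 1 gives 2800 nM. Compound 2 `O=C(Nc1cc(C(F)(F)F)cc(C(F)(F)F)c1)c1cnc(Cl)nc1C(F)(F)F` carries the same amide but a different aryl group, and in this assay compound 2 gives 50 nM, the lowest of the two numbers shown; compound 1 sits at a higher number, and the gap between them is well beyond the scatter. The two differ in more than one place, so no single step can be read from them.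

Compound 3 `O=C(OC1CCCCC1)c1cc(NC(=O)c2cnc(Cl)nc2C(F)(F)F)cc(C(F)(F)F)c1` keeps the core and one trifluoromethyl group of compound 2 and changes one position: cyclohexyloxycarbonyl in place of trifluoromethyl on an aromatic carbon. Within the data shown here, no measured pair shows this kind of exchange, so there is no step to lean on; the only anchor is the value of compound 2. Compound 3 is expected to give a somewhat higher number than compound 2 in this assay, a step of a 3.0-fold higher number from compound 2 to compound 3 (0.48 log units; beyond the scatter) that is estimated to lie near the edge of the scatter. Compound 3 is therefore estimated at 150 nM, within a range from 30 nM to 800 nM.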

Compound 3, half-maximal inhibitory concentration: 1200 nM
The estimate for compound 3 lay 8.0-fold (0.90 log units) below the measured number, outside the stated range (above it).
By their numbers in this assay, from the lowest: compound 2; then compound 3; then compound 1.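

In this assay the aromatic carbon meta to a trifluoromethyl group now has its first reading from a change in one place: cyclohexyloxycarbonyl in place of trifluoromethyl gives a 24-fold higher number from compound 2 to compound 3 (1.38 log units; beyond the scatter) and this large step lies beyond the scatter. Among these compounds, the earlier pair differed in more than one place, so only this step ties a change in the number to this position, and it shows that the number here responds strongly to what sits on that carbon while the shared core and the other trifluoromethyl group stay the same. Nothing measured here bears on why the number rises.

A single step cannot separate the part played by the six-membered ring from that of the carbonyl and its oxygen, and a carboxylic acid, a methyl ester or an amine on the same carbon would each give a separate reading of this position. Going by these compounds, it also remains open whether the same exchange would give a step of similar size with the other trifluoromethyl group replaced by a nitrile or a chlorine.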